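Compound 4: A Methyl Added Where Compound 3 Has Hydrogen

The source may hold more compounds than are shown below. What is called first, only, known or untested is meant among the compounds shown, and "the series" means these compounds.

Of the compounds shown here, three of one series have been tested in an ADME assay on A-431 cells (Homo sapiens) for cytotoxicity, with a stated time of 48 h; on this read-out higher numbers stand for weaker inhibition and lower numbers for stronger inhibition. Compound 1 `O=[N+]([O-])c1cc(CSc2nnc(-c3ccc(Cl)cc3)n2Cc2ccccc2)cc([N+](=O)[O-])c1` gives > 30000 nM in this assay, a limit of the assay rather than a number. Compound 2 `O=[N+]([O-])c1cc(CSc2nnc(-c3ccc(Cl)cc3)n2Cc2ccccc2)cc(C(F)(F)F)c1` gives > 30000 nM in this assay, again a limit. Among the measured compounds shown here, the one change between them, trifluoromethyl in place of nitro on an aromatic carbon, yields a step that the two limits leave unreadable from compound 1 to compound 2. Compound 3 `Cn1c(SCc2ccccc2)nnc1-c1cc([N+](=O)[O-])cc([N+](=O)[O-])c1` gives > 30000 nM in this assay, once more a limit. For the measured compounds named here, compound 3 thus stands where every value so far sits, at the limit of > 30000 nM in this assay, at which 3 of the 3 values shown sit, and no readable step separates it from the others.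

Compound 4 `CCn1c(SCc2ccccc2)nnc1-c1cc([N+](=O)[O-])cc([N+](=O)[O-])c1` differs from compound 3 by methyl in place of hydrogen on a saturated chain carbon bound to an aromatic nitrogen. Going by the values given here, no measured step bears on this change; the one measured step concerns another position and is itself unreadable. With all values at the limit, the expected step is a step that the limit leaves unreadable from compound 3 to compound 4, which is to say none beyond the scatter. Compound 4 is therefore estimated at 50000 nM in this assay, between 20000 nM and 200000 nM, most likely reported again as a limit.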

Compound 4, half-maximal inhibitory concentration: > 30000 nM
Compound 4: only a limit was reported; the forecaster's own chance of this, stated with the estimate: 90%; the middle value does not contradict the limit.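

The values of compound 3 and compound 4 in this assay are both limits, and no step can be read between them. The compounds shown leave open what size of step either single change carries, as every value stands at one limit: the limit of > 30000 nM in this assay, at which 4 of the 4 values shown sit.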